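From Trifluoromethyl to Trifluoromethoxy: Expecting Compound 4

This account rests on a few compounds, and the source may have more. Where it says the series, first, only, none or still open, it means among the compounds named here.

Of the compounds shown here, three built on one shared core have been tested in a functional assay on HEK293 cells for antagonist activity at transient receptor potential M8 protein (Canis lupus familiaris), read by FLIPR and calcium flux; on this read-out higher numbers stand for weaker inhibition and lower numbers for stronger inhibition. Compound 1 `Fc1ccccc1-c1ccc2[nH]c(C3=NOC4(CCCCC4)C3)nc2c1` gives 2.9 nM. Compound 2 `FC(F)(F)Oc1ccccc1-c1ccc2[nH]c(C3=NOC4(CCCCC4)C3)nc2c1` gives 1.1 nM, and compound 3 `Fc1cccc(C(F)(F)F)c1-c1ccc2[nH]c(C3=NOC4(CCCCC4)C3)nc2c1` gives 0.6 nM. Compound 3 sits at the low end of the three: its gap to compound 1 is beyond the scatter, while compound 2 lies within the scatter of it. Compound 4 `Fc1cccc(OC(F)(F)F)c1-c1ccc2[nH]c(C3=NOC4(CCCCC4)C3)nc2c1` has not yet been measured. It differs from compound 3 by trifluoromethoxy in place of trifluoromethyl on an aromatic carbon. Among the compounds with values here, no measured step exchanges these two groups directly. Within the data shown here, two steps bear on it in part: a 2.6-fold lower number from compound 1 to compound 2 (0.42 log units; beyond the scatter) and a 4.8-fold lower number from compound 1 to compound 3 (0.68 log units; beyond the scatter), both modest and both toward lower numbers. Compound 2 and compound 3 differ in more than one place, and their values sit within the scatter of each other. On that basis compound 4 is estimated at 0.8 nM, within a range from 0.35 nM to 1.8 nM. The step of a 1.3-fold higher number from compound 3 to compound 4 (0.12 log units; within the scatter) is thus expected to stay within the scatter.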

Compound 4, half-maximal inhibitory concentration: 0.8 nM
The estimate for compound 4 equals the measured number at the digits printed; the range from low to high includes it.
By their numbers in this assay, from the lowest: compounds 3, 4 and 2 (each within the scatter of the next); then compound 1.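

In this assay, trifluoromethoxy in place of trifluoromethyl on this aromatic carbon, ortho to a large group and meta to a fluoro group, gives a 1.3-fold higher number from compound 3 to compound 4 (0.12 log units; within the scatter), so the two groups cannot be told apart at this place. Fluoro in place of hydrogen on an aromatic carbon gives a 1.4-fold lower number from compound 2 to compound 4 (0.14 log units; within the scatter), which also lies within the scatter, whereas the remaining step is a 3.6-fold lower number from compound 1 to compound 4 (0.56 log units; beyond the scatter), which lies beyond it. No measurement at hand offers an explanation for these steps.

The compounds shown leave open whether a methoxy group, a nitrile or an amine at this place would give a number in the same range. They also leave open whether these steps would hold on a different core.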